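A few compounds are considered here, and "the series" means these few. Any claim that something is new, unique, unknown or untested is made for them only; others in the source may bear on it.

Compound 3 `CC(C)c1nc(SCc2ccc(-c3ccccc3C#N)cc2)c2ccccc2n1` is one of three close relatives tested in an assay on isolated protein for inhibition of phosphodiesterase 7 (Homo sapiens), read by scintillation proximity assay and cAMP accumulation, with a stated time of 1 h; a higher number here means a weaker inhibitor, a lower number a stronger inhibitor. In this assay compound 3 gives only a limit, > 100000 nM. Compound 1 `Cc1nc(SCc2ccc(-c3ccccc3C#N)cc2)c2ccccc2n1` likewise reaches only a limit, > 100000 nM. Compound 2 `N#Cc1ccccc1-c1ccc(CSc2nc(C(Cl)(Cl)Cl)nc3ccccc23)cc1` again shows only a limit, > 100000 nM. All three therefore stand together at the limit of > 100000 nM in this assay, at which 3 of the 3 values shown sit, and the steps a step that the two limits leave unreadable from compound 1 to compound 2, a step that the two limits leave unreadable from compound 1 to compound 3 and a step that the two limits leave unreadable from compound 2 to compound 3 cannot be read from such limits. Compound 4 `N#Cc1ccccc1-c1ccc(CSc2nc(SCc3ccc(F)cc3)nc3ccccc23)cc1` differs from compound 3 in one place: (4-fluorobenzyl)sulfanyl in place of isopropyl on an aromatic carbon. Among the compounds with values here, no measured step speaks to this change, so the expected step of an at least 1.6-fold lower number from compound 3 to compound 4 (0.22 log units; that floor lies within the scatter) rests on the shared core alone and is most likely small or none beyond the scatter. Compound 4 is estimated at 60000 nM in this assay, within a range of 5000 nM to 300000 nM.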

Compound 4, half-maximal inhibitory concentration: > 100000 nM
Compound 4: a limit, no number; the forecaster's own chance of this, stated with the estimate: 60%; at least 1.6-fold (0.22 log units) between middle value and limit.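

In this assay compound 4 also gives only a limit, > 100000 nM. The steps to compound 4 from compound 1, compound 2 and compound 3 therefore cannot be read: the limit of > 100000 nM in this assay, at which 4 of the 4 values shown sit.

The compounds shown leave open whether any group at this place gives a measurable inhibitory concentration.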